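The source may hold more compounds than are shown below. What is called first, only, known or untested is meant among the compounds shown, and "the series" means these compounds.

Measured so far in a functional assay on K562 cells (Homo sapiens) for cytotoxicity, read by MTT assay, with a stated time of 5 days; on this read-out higher numbers stand for weaker inhibition and lower numbers for stronger inhibition:
- compound 1 `COc1ccc(Cn2nncc2-c2cc(OC)c(OC)c(OC)c2)cc1Br` gives > 10000 nM
- compound 2 `COc1ccc(Cn2nncc2-c2cc(OC)c(OC)c(OC)c2)cc1[N+](=O)[O-]` gives > 10000 nM

Compound 2 stands only at a limit, > 10000 nM, and this is not a number. The same holds across the pair, which offers a single reading: the limit of > 10000 nM in this assay, at which 2 of the 2 values shown sit. For the measured compounds named here, the one measured step, nitro in place of bromo, is a step that the two limits leave unreadable from compound 1 to compound 2, so it hands on no size to work from.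

Compound 3 `COc1ccc(Cn2nncc2-c2cc(OC)c(OC)c(OC)c2)cc1N` carries amino in place of the nitro of compound 2, on an aromatic carbon ortho to a methoxy group: amino in place of nitro on an aromatic carbon. Neither the size nor the direction of this change in this assay can be read from the data, so compound 3 is expected to stay near the limit, with a modest gain possible. The expected change is an at least 2.0-fold lower number from compound 2 to compound 3 (0.30 log units; that floor lies within the scatter). For compound 3 the estimate is 5000 nM, with an expected range from 300 nM to 20000 nM.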

Compound 3, half-maximal inhibitory concentration: 730 nM
Estimate against measurement, compound 3: 6.8-fold (0.84 log units) above; low and high end bracket the measured number.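

In this assay, this position, ortho to a methoxy group, proves responsive to the group it carries: amino in place of nitro gives an at least 13-fold lower number from compound 2 to compound 3 (1.13 log units; beyond the scatter), and amino in place of bromo gives an at least 13-fold lower number from compound 1 to compound 3 (1.13 log units; beyond the scatter). Compound 3 is the only one of the three with an actual number, so the change now has a direction, whereas the step between compound 1 and compound 2 cannot be read. Both new steps give only a minimum size, because each starts from a limit and not from a number: the limit of > 10000 nM in this assay, at which 2 of the 3 values shown sit.

The compounds shown leave open how far the gain depends on the amino group itself, as opposed to the loss of bromo or nitro. On these data alone, whether a hydroxyl, a methylamino group or an acetamide at this position would match compound 3 also remains unknown.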